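This account rests on a few compounds, and the source may have more. Where it says the series, first, only, none or still open, it means among the compounds named here.

Working notes on a short series built on the same hydroxynaphthoquinone-bearing core, all tested in a functional assay on KB cells (Homo sapiens) for cytotoxicity, read by resazurin assay, with a stated time of 3 days; a lower number here means a stronger inhibitor, a higher number a weaker inhibitor.

Compound 1 `CC(C)(CNC(=O)c1ccccc1)CC1=C(O)C(=O)c2ccccc2C1=O` is the plainest member, carrying an unsubstituted benzamide. In this assay compound 1 gives 15200 nM. Compound 3 `COc1ccccc1C(=O)NCC(C)(C)CC1=C(O)C(=O)c2ccccc2C1=O` differs from it only by methoxy in place of hydrogen on an aromatic carbon, and in this assay compound 3 gives 26300 nM; the step of a 1.7-fold higher number from compound 1 to compound 3 (0.24 log units; within the scatter) is small, so the methoxy group at that place neither helps nor hurts in a way that can be resolved.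

Compound 2 `CC(C)(CNC(=O)c1ccc2ccccc2c1O)CC1=C(O)C(=O)c2ccccc2C1=O` carries a different amide part; the difference between its core and the core of compound 1 is not broken down here. In this assay compound 2 gives 26900 nM, and its values stand close to those of compound 1 and compound 3 without a gap that exceeds the usual scatter.

Compound 4 `COc1cc(C(=O)NCC(C)(C)CC2=C(O)C(=O)c3ccccc3C2=O)c(O)c2ccccc12` is the not yet measured analogue of compound 2 and differs from it by methoxy in place of hydrogen on an aromatic carbon. This is the same kind of change as that from compound 1 to compound 3, though not the same: there the entering methoxy sat ortho to a large group on a single six-membered ring, while here it sits on a fused system, ortho to a fused ring, meta to a fused ring, meta to a large group and para to a hydroxy group. Because the earlier step of a 1.7-fold higher number from compound 1 to compound 3 (0.24 log units; within the scatter) stayed inside the scatter, the expected step for compound 4 is likewise small, a 1.2-fold higher number from compound 2 to compound 4 (0.08 log units; within the scatter). For compound 4 in this assay the estimate is 32000 nM, expected to fall between 14000 nM and 70000 nM.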

Compound 4, half-maximal inhibitory concentration: 8620 nM
Estimate against measurement, compound 4: 3.7-fold (0.57 log units) above, outside the stated range (below it).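

In this assay, methoxy in place of hydrogen on an aromatic carbon does not carry over unchanged from one core to the other, and the new step, a 3.1-fold lower number from compound 2 to compound 4 (0.49 log units; beyond the scatter), differs from the earlier one: the same change on two cores in this assay, a 1.7-fold higher number (0.24 log units; within the scatter) from compound 1 to compound 3 and a 3.1-fold lower number (0.49 log units; beyond the scatter) from compound 2 to compound 4, 5.4-fold (0.73 log units) apart, beyond the scatter of two such steps

In compound 4 the methoxy sits on a fused system, para to a hydroxy group, so the surroundings of the aromatic carbon differ along with the core, and these two steps do not tell which of those differences matters. Going by these compounds alone, with only one such pair on each core, the result shows that the effect of this change depends on its setting within these compounds, but it gives no cause for the lower number of compound 4 and no basis for predicting the step on any further core.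

As far as these compounds go, it remains open whether the lower number of compound 4 is specific to methoxy or would also appear with an ethoxy group or a chlorine atom at the same place. From the compounds shown here alone, it is also open whether the step depends on the hydroxy group, which a core carrying the same methoxy but a hydrogen in place of that hydroxy group could address.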